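From Methoxymethyl to Ethoxymethyl on the Shared Core

The source may report more compounds than this note shows. Statements on the series, on what has been measured and on what is new or still open speak of the compounds shown alone.

In an in vitro ADME assay on microsomes from liver (Homo sapiens) for metabolic stability, with a stated time of 15 min (a higher number here means faster removal of the compound, a lower number slower removal), compound 1 (`CCc1nn2c(-c3c(OC)cc(C)cc3OC)cccc2c1N(CC1CCOCC1)CC1CC1`) gives 440 mL.min-1.g-1, compound 2 (`CCc1nn2c(-c3c(OC)cccc3OC)cccc2c1N(CC1CCOCC1)CC1CC1`) gives 740 mL.min-1.g-1 and compound 3 (`CCc1nn2c(-c3c(OC)cc(COC)cc3OC)cccc2c1N(CC1CCOCC1)CC1CC1`) gives 300 mL.min-1.g-1. Compound 3 thus stands within the scatter of compound 1 but clearly apart from compound 2. Compound 4 (`CCOCc1cc(OC)c(-c2cccc3c(N(CC4CCOCC4)CC4CC4)c(CC)nn23)c(OC)c1`) turns methoxymethyl into ethoxymethyl: methyl in place of hydrogen on a saturated chain carbon bound to an oxygen on a saturated carbon. Going by the values given here, no measured step makes this exact change. The closest are a 1.5-fold lower number from compound 1 to compound 3 (0.17 log units; within the scatter) and a 2.5-fold lower number from compound 2 to compound 3 (0.39 log units; beyond the scatter), both ending in the methoxymethyl group, and they offer only a scale. The expected step is therefore small, a 1.1-fold higher number from compound 3 to compound 4 (0.05 log units; within the scatter), and is not expected to leave the scatter. For compound 4 the estimate is 340 mL.min-1.g-1, with an expected range from 180 mL.min-1.g-1 to 620 mL.min-1.g-1.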

Compound 4, intrinsic clearance in microsomes: 520 mL.min-1.g-1
For compound 4 the middle estimate is 1.5-fold (0.18 log units) below the measured one; the range from low to high includes it.
By their numbers in this assay, from the lowest: compounds 3, 1, 4 and 2 (each within the scatter of the next, the first and the last beyond it).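

In this assay the added methyl gives a 1.7-fold higher number from compound 3 to compound 4 (0.24 log units; within the scatter) and so keeps the change from methoxymethyl to ethoxymethyl within the scatter. Set against hydrogen on the aromatic carbon, where methoxymethyl went beyond the scatter, ethoxymethyl gives a 1.4-fold lower number from compound 2 to compound 4 (0.15 log units; within the scatter) and stays within it, and set against methyl it gives a 1.2-fold higher number from compound 1 to compound 4 (0.07 log units; within the scatter) and also stays within it. Nothing at hand explains these numbers. On these data alone, whether a longer chain or an amine at the end of this group would stay within the scatter remains open.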